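Cytotoxicity limits in the series: fluoro to methoxy

This account rests on a few compounds, and the source may have more. Where it says the series, first, only, none or still open, it means among the compounds named here.

- Compound 1 `COc1ccc(CC[C@H](O)C[C@H](O)c2cc(-c3ccc(OC)cc3)on2)cc1`: > 100000 nM
- Compound 2 `O[C@@H](CCc1ccc(F)cc1)C[C@H](O)c1cc(-c2ccccc2)on1`: > 100000 nM

In an ADME assay on HepG2 cells (Homo sapiens) for cytotoxicity, read by MTT assay, with a stated time of 24 h (a higher number here means a weaker inhibitor, a lower number a stronger inhibitor), compound 2 gives > 100000 nM, which is a limit and not a number. For the measured compounds named here, compound 2 therefore shares its standing with the only other measured compound: the limit of > 100000 nM in this assay, at which 2 of the 2 values shown sit.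

Compound 3 `COc1ccc(CC[C@H](O)C[C@H](O)c2cc(-c3ccccc3)on2)cc1` carries methoxy in place of fluoro on an aromatic carbon, para to a large group (methoxy in place of fluoro on an aromatic carbon). Compound 1 also has a methoxy there, and its > 100000 nM is likewise a limit. The expected step in this assay is a step that the limit leaves unreadable from compound 2 to compound 3, with no direction and nothing beyond the scatter, and another limit is likely. Compound 3 is estimated at 120000 nM, within a range of 60000 nM to 250000 nM.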

Compound 3, half-maximal inhibitory concentration: > 100000 nM
Compound 3 gave a limit, no number (the forecaster's own chance of this, stated with the estimate: 85%); the middle value does not contradict the limit.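

No step can be read between compound 1, compound 2 and compound 3, as all three stand at one limit: the limit of > 100000 nM in this assay, at which 3 of the 3 values shown sit.

Left open is whether the exchanges among fluoro, methoxy and hydrogen change the result in this assay at all.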